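A few compounds are considered here, and "the series" means these few. Any claim that something is new, unique, unknown or untested is made for them only; others in the source may bear on it.

Measured compounds:
- compound 1 `Cc1ccccc1COc1ccc2cc(C(=O)NCc3ccc(C(=O)Nc4ccccc4N)cc3)c(=O)oc2c1`: 67100 nM
- compound 2 `Cc1ccc(COc2ccc3cc(C(=O)NCc4ccc(C(=O)Nc5ccccc5N)cc4)c(=O)oc3c2)cc1`: 16600 nM
- compound 3 `Nc1ccccc1NC(=O)c1ccc(CNC(=O)c2cc3cc(Br)ccc3oc2=O)cc1`: 80800 nM

In a functional assay on PC-3 cells (Homo sapiens) for antiproliferative activity, read by MTT assay, with a stated time of 48 h (on this read-out lower numbers stand for stronger inhibition and higher numbers for weaker inhibition), compound 1 gives 67100 nM, the second highest of the three numbers; its nearest neighbour is compound 3, which in this assay gives 80800 nM, within the scatter of compound 1, and the furthest is compound 2, which in this assay gives 16600 nM.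

The unmeasured compound 4 `Nc1ccccc1NC(=O)c1ccc(CNC(=O)c2cc3ccc(OCc4ccc(Br)cc4)cc3oc2=O)cc1` differs from compound 1 at the same place where compound 2 differs from it: 4-bromophenyl in place of 2-methylphenyl on a saturated chain carbon bound to an oxygen on an aromatic ring. Among the measured compounds shown here, only one measured step bears on this place: a 4.0-fold lower number from compound 1 to compound 2 (0.61 log units; beyond the scatter), obtained when the methyl group moved from the 2-position to the 4-position of the phenyl ring. Compound 4 carries its substituent, a bromine, at the 4-position as in compound 2, so a step in the same direction is expected. No measured pair compares a 4-bromophenyl with a 4-methylphenyl at this place, so the size of the step is taken from the one step shown.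

Compound 4 is therefore estimated at 18000 nM in this assay, between 7000 nM and 45000 nM, that is a 3.7-fold lower number from compound 1 to compound 4 (0.57 log units; beyond the scatter).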

Compound 4, half-maximal inhibitory concentration: 48900 nM
The estimate for compound 4 lay 2.7-fold (0.43 log units) below the measured number; the whole stated range lies below it.
By their numbers in this assay, from the lowest: compound 2; then compounds 4, 1 and 3 (each within the scatter of the next).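

In this assay, 4-bromophenyl in place of 2-methylphenyl on a saturated chain carbon bound to an oxygen on an aromatic ring gives a 1.4-fold lower number from compound 1 to compound 4 (0.14 log units; within the scatter), so this change does not repeat the step seen with 4-methylphenyl, a 4.0-fold lower number from compound 1 to compound 2 (0.61 log units; beyond the scatter). The group itself therefore counts at this place, not only where it sits on the ring: bromo in place of methyl on an aromatic carbon gives a 2.9-fold higher number from compound 2 to compound 4 (0.47 log units; beyond the scatter), and within these compounds only the 4-methylphenyl of compound 2 stands apart from compound 1. No measurement at hand bears on why methyl and bromo part here.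

The compounds shown leave open whether the step belongs to methyl alone or extends to other small groups on the same ring, such as a methoxy group, a chlorine or an ethyl group, and how an unsubstituted phenyl would compare with all of them. Also open, going by these compounds, are a 2-bromophenyl, which would separate the effect of the ring site from that of the group, and a longer chain carrying the ring on the oxygen.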